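A few compounds are considered here, and "the series" means these few. Any claim that something is new, unique, unknown or untested is made for them only; others in the source may bear on it.

Notes on the series. In an assay on isolated protein for inhibition of glutathione S-transferase P (Homo sapiens), with a stated time of 10 min (on this read-out lower numbers stand for stronger inhibition and higher numbers for weaker inhibition), compound 1 `Cc1ccccc1NC(=O)CCC(=O)OCCCCCCSc1ccc([N+](=O)[O-])c2nonc12` gives 4100 nM, and compound 2 `O=C(CCC(=O)OCCCCCCSc1ccc([N+](=O)[O-])c2nonc12)Nc1cccc(Cl)c1` gives 28800 nM. Within the data shown here, compound 2 stands at the highest of the two numbers, with compound 1 the nearest; the only measured step is a 7.0-fold higher number from compound 1 to compound 2 (0.85 log units; beyond the scatter), a change of one aryl substituent for another on the amide-type nitrogen.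

Compound 3 `O=C(CCC(=O)N1CCOCC1)OCCCCCCSc1ccc([N+](=O)[O-])c2nonc12` differs from compound 2 in one place: morpholin-4-yl in place of (3-chlorophenyl)amino on a carbonyl carbon. This exchanges an aryl-bearing amide nitrogen for a saturated ring nitrogen, a change of a different kind from the one measured, so the step from compound 1 to compound 2 bears only loosely on it and gives no direction. Among the measured compounds shown here, no step of this kind is known; the expectation therefore rests on compound 2 alone. In this assay compound 3 is expected near the value of compound 2, which means an expected step of a 1.4-fold lower number from compound 2 to compound 3 (0.16 log units; within the scatter), with the estimate 20000 nM in the range 5000 nM to 80000 nM.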

Compound 3, half-maximal inhibitory concentration: 330 nM
The estimate for compound 3 lay 61-fold (1.78 log units) above the measured number; the whole stated range lies above it.
By their numbers in this assay, from the lowest: compound 3; then compound 1; then compound 2.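

Morpholin-4-yl in place of (3-chlorophenyl)amino on a carbonyl carbon brings an 87-fold lower number from compound 2 to compound 3 (1.94 log units; beyond the scatter), and in place of (2-methylphenyl)amino it brings a 12-fold lower number from compound 1 to compound 3 (1.09 log units; beyond the scatter). Both earlier compounds carry an aryl group and the amide hydrogen at this position, whereas compound 3 carries neither, so in this assay neither feature is required for the lowest number among the three compounds. Nothing at hand bears on the reason for these steps.

The compounds shown leave open whether the gain belongs to the morpholine ring oxygen, to the ring itself or to the loss of the aryl group and the amide hydrogen. Piperidin-1-yl, dimethylamino and N-methyl-N-phenylamino groups on the same carbonyl carbon would help to separate these possibilities.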